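One Aryl Swap, Two Cores: Estimating Compound 4

The compounds below may be only part of what the source reports. "The series", "measured", "known", "first", "only" and "open" are said of these compounds alone.

Three compounds have been measured in an assay on CHO-K1 cells for antagonist activity at transient receptor potential cation channel subfamily V member 1 (Homo sapiens), read by FLIPR and calcium flux, with a stated time of 6 min; on this read-out higher numbers stand for weaker inhibition and lower numbers for stronger inhibition:

compound 1 `O=C(NCc1cc(C(F)(F)F)nn1-c1cccc(C(F)(F)F)c1)Nc1cccc2[nH]ncc12`: 1.3 nM
compound 2 `O=C(NCc1cc(C(F)(F)F)nn1-c1ccc(Cl)cc1)Nc1cccc2[nH]ncc12`: 2.5 nM
compound 3 `Cn1ncc2c(NC(=O)NCc3cc(C(C)(C)C)nn3-c3cccc(C(F)(F)F)c3)cccc21`: 0.6 nM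

Compound 2 is compound 1 with 4-chlorophenyl in place of 3-(trifluoromethyl)phenyl on an aromatic nitrogen, and that step gave a 1.9-fold higher number from compound 1 to compound 2 (0.28 log units; within the scatter). Compound 3 carries a different core; how it differs from compound 1 is not broken down here, and its value in this assay is the lowest of the three.

Compound 4 `Cn1ncc2c(NC(=O)NCc3cc(C(C)(C)C)nn3-c3ccc(Cl)cc3)cccc21` has not yet been measured. It is compound 3 with 4-chlorophenyl in place of 3-(trifluoromethyl)phenyl on an aromatic nitrogen. This is the same kind of change as from compound 1 to compound 2, though the surroundings differ: in compound 3 the place is two ring bonds from the ring atom that bears a tert-butyl group, whereas in compound 1 it is two ring bonds from the ring atom that bears a trifluoromethyl group.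

Taking the earlier step as a guide, compound 4 is expected to show a 1.8-fold higher number from compound 3 to compound 4 (0.26 log units; within the scatter) in this assay, because compound 1 to compound 2 gave a 1.9-fold higher number from compound 1 to compound 2 (0.28 log units; within the scatter). The estimate for compound 4 is 1.1 nM, within 0.4 nM to 3.5 nM.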

Compound 4, inhibition constant: 9.5 nM
Compound 4: middle estimate off by 8.6-fold (0.94 log units), on the low side; the measured number lies above the stated range.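

In this assay, putting 4-chlorophenyl in place of 3-(trifluoromethyl)phenyl on the aromatic nitrogen gave a 16-fold higher number from compound 3 to compound 4 (1.20 log units; beyond the scatter), a large loss of inhibition from a change that made little measurable difference on the core of compound 1. Among these compounds, this does not show which difference between the cores sets the size of the step, since they differ in more than one place and only two pairs carry this swap. What it does show is that, in this series, the size of this step did not carry over from one core to the other, so a step measured on one core is a weak guide to the next: the same change on two cores in this assay, a 1.9-fold higher number (0.28 log units; within the scatter) from compound 1 to compound 2 and a 16-fold higher number (1.20 log units; beyond the scatter) from compound 3 to compound 4, 8.2-fold (0.92 log units) apart, beyond the scatter of two such steps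

Still open, as far as these compounds go, is how the swap behaves when an isopropyl or cyclopropyl group stands in place of tert-butyl. A smaller change to that group might show whether the step shrinks gradually or stays large.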